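Methoxy for Dimethylcarbamoyl on Two Related Cores

This account rests on a few compounds, and the source may have more. Where it says the series, first, only, none or still open, it means among the compounds named here.

Compound 1 `CN(C)C(=O)c1coc(C(=O)CCCCCCc2ccccc2)n1`: in an assay on HEK-293T cells for inhibition of diacylglycerol lipase-alpha (Homo sapiens), read by colorimetric assay (on this read-out higher numbers stand for weaker inhibition and lower numbers for stronger inhibition), compound 1 gives 3390 nM.
Compound 2 `COc1coc(C(=O)CCCCCCc2ccccc2)n1`: in this assay compound 2 gives > 10000 nM, a limit of the assay and not a number.
Compound 3 `CN(C)C(=O)c1cnc(C(=O)CCCCCCc2ccccc2)o1`: in this assay compound 3 gives > 10000 nM, likewise a limit and not a number.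

Compound 1 and compound 3 are built from the same atoms joined differently; how their two cores differ is not broken down here. Within the core of compound 1, the single change from compound 1 to compound 2 is methoxy in place of dimethylcarbamoyl on an aromatic carbon, and it made an at least 2.9-fold higher number from compound 1 to compound 2 (0.46 log units; beyond the scatter). The same kind of change is now to be made on the core of compound 3, giving compound 4 `COc1cnc(C(=O)CCCCCCc2ccccc2)o1`; here the change is methoxy in place of dimethylcarbamoyl on an aromatic carbon. The surroundings are not identical: in compound 1 the changed carbon sits next to the ring nitrogen and two ring bonds from the ring oxygen, whereas in compound 3 it sits next to the ring oxygen and two ring bonds from the ring nitrogen.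

Compound 3 already sits at the limit of > 10000 nM in this assay, at which 2 of the 3 values shown sit. With the change from compound 1 to compound 2 pointing toward weaker inhibition, compound 4 is expected to move in that same direction, by an estimated step that the limit leaves unreadable from compound 3 to compound 4, resting on an at least 2.9-fold higher number from compound 1 to compound 2 (0.46 log units; beyond the scatter) and on compound 3 giving > 10000 nM. Compound 4 is therefore estimated at 30000 nM, between 10000 nM and 100000 nM, most likely reported only as a limit.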

Compound 4, half-maximal inhibitory concentration: > 10000 nM
Compound 4: no number, only a limit; the forecaster's own chance of this, stated with the estimate: 90%; the middle value does not contradict the limit.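

No new step can be read: the steps from compound 3 to compound 4 and from compound 2 to compound 4 stay unreadable, because all three compounds give only a limit and not a number: the limit of > 10000 nM in this assay, at which 3 of the 4 values shown sit. The compounds shown leave open whether methoxy in place of dimethylcarbamoyl on an aromatic carbon changes inhibition on the core of compound 3, and how compound 2, compound 3 and compound 4 compare.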